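The source may report more compounds than this note shows. Statements on the series, on what has been measured and on what is new or still open speak of the compounds shown alone.

Measured so far in an ADME assay on Caco-2 cells (Homo sapiens) for permeability, read by LC-MS, in the apical to basolateral direction, with a stated time of 2 h, tested at 2 uM; a lower number here means that the compound crosses the layer more slowly, a higher number that the compound crosses the layer faster:
- compound 1 `CC[C@@H](Nc1c(C#N)c(-c2ccc(-c3ccc(OC)cc3)cc2)nc2cnccc12)C(N)=O`: 114 nm/s
- compound 2 `CCOc1ccccc1-c1ccc(-c2nc3cnccc3c(N[C@H](CC)C(N)=O)c2C#N)cc1`: 151 nm/s
- compound 3 `CC[C@@H](Nc1c(C#N)c(-c2ccc(-c3ccc(Cl)cc3)cc2)nc2cnccc12)C(N)=O`: 29 nm/s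

Compound 3 stands lowest of the three at 29 nm/s, and both of its gaps to the others lie beyond the scatter. Compound 4 `CC[C@@H](Nc1c(C#N)c(-c2ccc(-c3ccccc3OC)cc2)nc2cnccc12)C(N)=O` differs from compound 3 in one place, with 2-methoxyphenyl in place of 4-chlorophenyl on an aromatic carbon, para to a large group: 2-methoxyphenyl in place of 4-chlorophenyl on an aromatic carbon.

Going by the values given here, three measured steps bear on this change. Two run towards the chloro compound and are modest: a 3.9-fold lower number from compound 1 to compound 3 (0.59 log units; beyond the scatter) and a 5.2-fold lower number from compound 2 to compound 3 (0.72 log units; beyond the scatter). Compound 4 resembles compound 1 and compound 2 more closely than compound 3, and those two sit within the scatter of each other: a 1.3-fold higher number from compound 1 to compound 2 (0.12 log units; within the scatter). Read in reverse, the two modest steps suggest a rise of similar size beyond the scatter in this assay. The expected step is a 4.5-fold higher number from compound 3 to compound 4 (0.65 log units; beyond the scatter). For compound 4 the estimated value is 130 nm/s, with an expected range of 60 nm/s to 260 nm/s.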

Compound 4, apparent permeability: 160 nm/s
Estimate against measurement, compound 4: 1.2-fold (0.09 log units) below; low and high end bracket the measured number.
By their numbers in this assay, from the lowest: compound 3; then compounds 1, 2 and 4 (each within the scatter of the next).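

In this assay the result shows that a 2-methoxyphenyl group at this place, on an aromatic carbon para to a large group, stands well apart from 4-chlorophenyl, with a 5.5-fold higher number from compound 3 to compound 4 (0.74 log units; beyond the scatter) as the step. It also shows that moving the methoxy group makes no readable difference, with a 1.4-fold higher number from compound 1 to compound 4 (0.15 log units; within the scatter) as the step, and that the shorter ether makes none either, with a 1.1-fold higher number from compound 2 to compound 4 (0.03 log units; within the scatter) as the step. Among these four compounds, compound 3 alone stands apart, while 4-methoxyphenyl, 2-ethoxyphenyl and 2-methoxyphenyl cannot be told apart.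

The compounds shown leave open whether a fluoro group, an amine or a carboxylic acid on this ring would give a number near that of compound 3 or near those of the other three. Nothing shown accounts for the gap between 4-chlorophenyl and the ether-bearing groups.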